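Fluoro in Place of Hydrogen: Expected Cytotoxicity of Compound 3

The source may report more compounds than this note shows. Statements on the series, on what has been measured and on what is new or still open speak of the compounds shown alone.

In an ADME assay on PBMC cells (Homo sapiens) for cytotoxicity, read by CellTiter-Glo, with a stated time of 72 h (a lower number here means a stronger inhibitor, a higher number a weaker inhibitor), compound 2 `CO[C@@H]1[C@H](N(C)c2ncc(-c3c[nH]c4ccccc34)s2)C[C@H]2O[C@]1(C)n1c3ccccc3c3c4c(c5c6cc(Br)ccc6n2c5c31)C(=O)NC4` reaches only the limit > 10000 nM, not a number. Compound 1 `CO[C@@H]1[C@H](N(C)c2ncc(-c3c[nH]c4ccc(F)cc34)s2)C[C@H]2O[C@]1(C)n1c3ccccc3c3c4c(c5c6cc(Cl)ccc6n2c5c31)C(=O)NC4` likewise stops at the limit > 10000 nM in this assay. Among the measured compounds shown here, both measured values therefore sit at the limit of > 10000 nM in this assay, at which 2 of the 2 values shown sit, and no measured step between them exists. Compound 3 `CO[C@@H]1[C@H](N(C)c2ncc(-c3c[nH]c4ccc(F)cc34)s2)C[C@H]2O[C@]1(C)n1c3ccccc3c3c4c(c5c6cc(Br)ccc6n2c5c31)C(=O)NC4` differs from compound 2 by fluoro in place of hydrogen on an aromatic carbon. Because both measured values sit at the limit of > 10000 nM in this assay, at which 2 of the 2 values shown sit, the expected step that the limit leaves unreadable from compound 2 to compound 3 is none beyond the scatter. Compound 3 is thus expected to give 20000 nM in this assay, within 10000 nM to 100000 nM.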

Compound 3, half-maximal inhibitory concentration: > 10000 nM
Compound 3 was reported as a limit (the forecaster's own chance of this, stated with the estimate: 85%); the middle value is on the limit's open side.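

No step can be read between compound 1, compound 2 and compound 3, since each value is a limit and not a number: the limit of > 10000 nM in this assay, at which 3 of the 3 values shown sit.

Still open, as far as these compounds go, is whether fluoro in place of hydrogen, or bromo in place of chloro, changes cytotoxicity at all, and by how much.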